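Trimming a large aryl to methyl on the shared core

This account rests on a few compounds, and the source may have more. Where it says the series, first, only, none or still open, it means among the compounds named here.

Of the compounds shown here, two have been measured in a functional assay on KG-1a cells (Homo sapiens) for inhibition, read by MTT assay, with a stated time of 72 h; on this read-out lower numbers stand for stronger inhibition and higher numbers for weaker inhibition. Compound 1, `Cc1ccc(-n2cc(CCO)nn2)cc1Nc1nccc(-c2cccnc2)n1`, gives 6540 nM in this assay. Compound 2, `Cc1ccc(-c2nnc(-c3ccc(C)c(C(F)(F)F)c3)o2)cc1Nc1nccc(-c2cccnc2)n1`, reaches only the limit of this assay, reported as > 30000 nM, so no number is known for it. This places compound 2 at the weak end of the results shown, as the evidence that the limit of > 30000 nM in this assay, at which 1 of the 2 values shown sits, makes plain. Compound 3, `Cc1nnc(-c2ccc(C)c(Nc3nccc(-c4cccnc4)n3)c2)o1`, differs from compound 2 by methyl in place of 4-methyl-3-(trifluoromethyl)phenyl on an aromatic carbon. Among the compounds with values here, no measured step between two compounds here matches this change, so the expected size of the step is uncertain; since compound 2 sits at a limit, a change toward stronger inhibition would be the only kind that could show up as a number. The step is estimated as an at least 2.0-fold lower number from compound 2 to compound 3 (0.30 log units; that floor lies within the scatter). Compound 3 is expected to give about 15000 nM in this assay, within a range of 4000 nM to 50000 nM.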

Compound 3, half-maximal inhibitory concentration: 18000 nM
Compound 3: the middle estimate sits 1.2-fold (0.08 log units) below what was measured, within the range that was stated.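

Trimming 4-methyl-3-(trifluoromethyl)phenyl to methyl on this carbon of the five-membered ring gives a real number in this assay, and the change reads as an at least 1.6-fold lower number from compound 2 to compound 3 (0.22 log units; that floor lies within the scatter). Going by these compounds, compound 2 stands only as a limit, so this step is a floor and its true size stays unknown: the limit of > 30000 nM in this assay, at which 1 of the 3 values shown sits. Removing the large aryl still does not match the 4-(2-hydroxyethyl)-1H-1,2,3-triazol-1-yl compound, since the exchange for 5-methyl-1,3,4-oxadiazol-2-yl gives a 2.8-fold higher number from compound 1 to compound 3 (0.44 log units; beyond the scatter).

On these data alone, it remains open whether methyl is the best small group on this carbon, or whether an amine or a 2-hydroxyethyl chain there would give a lower number. The compounds shown also cannot separate the effect of the ring from that of the group it carries, as compound 1 and compound 3 differ in both.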